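A few compounds are considered here, and "the series" means these few. Any claim that something is new, unique, unknown or untested is made for them only; others in the source may bear on it.

Measured so far:

Compound 1, `CC(C)CCN(CCC(C)C)S(=O)(=O)NC(=O)Nc1c(C(C)C)cccc1C(C)C`, in an assay on liver for inhibition of sterol O-acyltransferase 1 (Rattus norvegicus), using microsomes; on this read-out higher numbers stand for weaker inhibition and lower numbers for stronger inhibition: 420 nM
Compound 2, `CC(C)c1cccc(C(C)C)c1OC(=O)NS(=O)(=O)N1CCCC1`, in this assay: 53000 nM
Compound 3, `COc1cc(C(C)(C)C)c(OC(=O)NS(=O)(=O)Nc2c(C(C)C)cccc2C(C)C)c(C(C)(C)C)c1`, in this assay: 15000 nM

Compound 2 stands at the highest number of the three in this assay, so it is the weakest inhibitor of the set; its nearest neighbour is compound 3 and the gap to it lies beyond the scatter, while compound 1 sits far lower. Compound 4, `CC(C)c1cccc(C(C)C)c1OC(=O)NS(=O)(=O)Oc1c(F)cccc1F`, is not yet measured. It differs from compound 2 in one place: 2,6-difluorophenoxy in place of pyrrolidin-1-yl on a sulfonyl sulfur. For the measured compounds named here, no measured pair of compounds that differs in one place is available, so the size of this step cannot be read from the set; what is known is only that compound 2 gives 53000 nM and that compound 3, which also carries a carbamate linked to a sulfonyl group, gives 15000 nM. On that basis a modest step towards stronger inhibition in this assay is expected, near the edge of the scatter, the expected step being a 2.7-fold lower number from compound 2 to compound 4 (0.42 log units; beyond the scatter). Compound 4 is estimated to give 20000 nM, in the range 5000 nM to 80000 nM.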

Compound 4, half-maximal inhibitory concentration: 38000 nM
Beside the measured number, compound 4's estimate is 1.9-fold (0.28 log units) below it; the measured number falls inside the stated range.
By their numbers in this assay, from the lowest: compound 1; then compound 3; then compounds 4 and 2 (each within the scatter of the next).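

In this assay, for the compounds shown here, the one readable single-place step is a 1.4-fold lower number from compound 2 to compound 4 (0.14 log units; within the scatter), so this change on a sulfonyl sulfur whose other neighbour is an amide-type nitrogen leaves the number within the scatter. Pyrrolidin-1-yl, a five-membered non-aromatic ring, and 2,6-difluorophenoxy, a six-membered aromatic ring, cannot be told apart at this position on this read-out, although they differ in ring type and in the linking atom. Nothing available explains why the step is this small.

As far as these compounds go, whether phenoxy without fluorine or a morpholin-4-yl ring on the same sulfonyl sulfur would move the number beyond the scatter stays open. Also open, from the compounds shown here alone, is whether 2,6-difluorophenoxy would give an equally small step on the core of compound 1.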